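Aryl amide variation in a sulfamoylurea series: compound 4

The source may hold more compounds than are shown below. What is called first, only, known or untested is meant among the compounds shown, and "the series" means these compounds.

Measured compounds:
compound 1 `COc1ccc(Cl)cc1C(=O)NCCC1CCN(S(=O)(=O)NC(=O)NC2CCCCC2)CC1` gives 25%
compound 2 `O=C(NC1CCCCC1)NS(=O)(=O)N1CCC(CCNC(=O)c2csnn2)CC1` gives 19%
compound 3 `O=C(NC1CCCCC1)NS(=O)(=O)N1CCC(CCNC(=O)c2ccc3ccccc3n2)CC1` gives 11%

All three numbers come from a functional assay on the whole organism (blood) with Rattus norvegicus as the target, with stated times of 24 h and 1 h, at a dose of 5 mg/kg by the intraperitoneal route; a higher number here means a stronger effect of the compound at the dose given, a lower number a weaker effect. Compound 3 holds the lowest number of the three; its gap to compound 2 lies within the scatter, while a number 14 percentage points lower from compound 1 to compound 3 (beyond the scatter) is a modest step beyond it. Compound 4 `O=C(NC1CCCCC1)NS(=O)(=O)N1CCC(CCNC(=O)c2cc(Cl)cc3cccnc23)CC1` differs from compound 3 by 6-chloroquinolin-8-yl in place of quinolin-2-yl on a carbonyl carbon. The bearing steps are the aryl swaps on this carbonyl: a number 6 percentage points lower from compound 1 to compound 2 (within the scatter) and a number 8 percentage points lower from compound 2 to compound 3 (within the scatter) fall within the scatter, and only a number 14 percentage points lower from compound 1 to compound 3 (beyond the scatter) exceeds it. Another aryl exchange is therefore expected to move this assay little, perhaps slightly upward given that compound 1 with a chlorine-bearing aryl gives 25%. Compound 4 is estimated at 15% (range 5% to 28%), an expected step of a number 4 percentage points higher from compound 3 to compound 4 (within the scatter) within the scatter.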

Compound 4, a percentage reported as activity, at one dose (the size of the read-out at that dose, not a potency): 52%
For compound 4 the middle estimate is 37 percentage points below the measured one, and the stated range ends below it.
By their numbers in this assay, from the lowest: compounds 3, 2 and 1 (each within the scatter of the next, the first and the last beyond it); then compound 4.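

On this carbonyl carbon, 6-chloroquinolin-8-yl in place of quinolin-2-yl brings a number 41 percentage points higher from compound 3 to compound 4 (beyond the scatter) in this assay, so a quinoline as such does not settle the read-out. The same group also stands clear of the other two aryl partners, with a number 33 percentage points higher from compound 2 to compound 4 (beyond the scatter) and a number 27 percentage points higher from compound 1 to compound 4 (beyond the scatter), the only rise on this carbonyl so far. No measurement shown accounts for this rise.

The change combines a chlorine with a different quinoline attachment point, and the compounds shown do not separate the two. Plain quinolin-8-yl or 6-fluoroquinolin-8-yl would bear on that question.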